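The compounds below may be only part of what the source reports. "The series", "measured", "known", "first", "only" and "open" are said of these compounds alone.

In a functional assay on THP-1 cells (Homo sapiens) for inhibition, read by sulforhodamine B assay, with a stated time of 48 h, tested at 50 uM (a higher number here means more inhibition of growth at the concentration tested, a lower number less inhibition of growth), compound 1 (`COc1cc(/C=C/C(=O)/C=C/c2cccc3ccccc23)ccc1OCc1cn(CCCCCOc2cc(=O)oc3ccccc23)nn1`) gives 44% and compound 2 (`COc1cccc(/C=C/C(=O)/C=C/c2ccc(OCc3cn(CCCCOc4cc(=O)oc5ccccc45)nn3)c(OC)c2)c1`) gives 47%, so these two values lie within the usual scatter of each other. Compound 3 (`COc1cc(/C=C/C(=O)/C=C/c2cc(OC)c(OC)c(OC)c2)ccc1OCc1cn(CCCCOc2cc(=O)oc3ccccc23)nn1`) has 3,4,5-trimethoxyphenyl in place of the 3-methoxyphenyl of compound 2, on a double-bonded chain carbon bound to a double-bonded chain carbon: 3,4,5-trimethoxyphenyl in place of 3-methoxyphenyl on a double-bonded chain carbon bound to a double-bonded chain carbon. Among the measured compounds shown here, no measured pair shows what this swap does, so no step beyond the scatter is expected in this assay. The estimated step of a number 3 percentage points higher from compound 2 to compound 3 (within the scatter) is therefore small. Compound 3 is expected at 50%, with an estimated range of 33% to 67%.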

Compound 3, percent growth inhibition at one concentration: 65%
Compound 3: the middle estimate sits 15 percentage points below what was measured, within the range that was stated.
By their numbers in this assay, from the lowest: compounds 1 and 2 (each within the scatter of the next); then compound 3.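

In this assay, putting 3,4,5-trimethoxyphenyl in place of 3-methoxyphenyl on a double-bonded chain carbon bound to a double-bonded chain carbon gives a number 18 percentage points higher from compound 2 to compound 3 (beyond the scatter). Among the compounds shown here, this is the first one-place comparison here, and it shows that growth inhibition responds to a change in this aryl group. Nothing available explains the rise. Going by these compounds, it remains open whether all the methoxy groups of compound 3 are needed, and whether a phenyl ring carrying a hydroxyl group or an amine at this place would match compound 3.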